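Lengthening the amide chain: what to expect for compound 4

The source may hold more compounds than are shown below. What is called first, only, known or untested is meant among the compounds shown, and "the series" means these compounds.

Compound 3, `CCCC(=O)NCCCCc1ccccc1OC`, gives the lowest of the two numbers measured in an assay for binding affinity to melatonin receptor (Gallus gallus) (a higher number here means a weaker inhibitor, a lower number a stronger inhibitor), with 116 nM. Its nearest neighbour is compound 2, `CCC(=O)NCCCCc1ccccc1OC`, which in this assay gives 339 nM. The step between the two is a 2.9-fold lower number from compound 2 to compound 3 (0.47 log units; beyond the scatter). Compound 1, `CCCCC(=O)NCCCc1ccccc1OC`, reaches only the limit of this assay, > 100000 nM (the limit of > 100000 nM in this assay, at which 1 of the 3 values shown sits), and that value is a limit rather than a number.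

Compound 4, `CCCCC(=O)NCCCCc1ccccc1OC`, has not yet been measured. Compared with compound 3 the change is methyl in place of hydrogen on a saturated chain carbon, three bonds along the chain from a carbonyl carbon. Among the compounds with values here, only one measured step resembles it, a methyl entering two bonds along the chain from the carbonyl carbon, and that step was a 2.9-fold lower number from compound 2 to compound 3 (0.47 log units; beyond the scatter). The change in compound 4 is of the same kind, cut one bond further out, and a smaller step in the same direction, or none beyond the scatter, is therefore expected rather than a repeat of the earlier gain. For compound 4 the expected step in this assay is a 1.7-fold lower number from compound 3 to compound 4 (0.22 log units; within the scatter). The estimate for compound 4 in this assay is 70 nM, with a range from 25 nM to 250 nM.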

Compound 4, inhibition constant: 9190 nM
Compound 4: middle estimate off by 130-fold (2.12 log units), on the low side, and the stated range ends below it.
By their numbers in this assay, from the lowest: compound 3; then compound 2; then compound 4. At a limit, above all of these: compound 1.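

Compound 4 shows that the position does not tolerate ever more chain in this assay: going from ethyl to propyl lowered the number (a 2.9-fold lower number from compound 2 to compound 3 (0.47 log units; beyond the scatter)), but the next change, propyl to butyl, reverses that direction and is much larger (a 79-fold higher number from compound 3 to compound 4 (1.90 log units; beyond the scatter)). The loss also more than cancels the earlier gain, so that the butyl compound stands well behind the ethyl compound (a 27-fold higher number from compound 2 to compound 4 (1.43 log units; beyond the scatter)). Across these three compounds, then, the response to chain length is not gradual, and a single methyl three bonds along the chain from the carbonyl carbon separates the best of them from a far weaker one; nothing given here accounts for this turn.

Going by these compounds, whether a longer chain such as pentyl would lose still more remains open, as does whether a branched isopropyl or a cyclopropyl group on the carbonyl would behave like propyl or like butyl. Also open, on these data alone, is whether the loss depends on chain length alone or would persist with an oxygen in the chain, as in a methoxymethyl group.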